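A Trifluoromethyl Added to a Non-Cytotoxic Hydrazone

The source may report more compounds than this note shows. Statements on the series, on what has been measured and on what is new or still open speak of the compounds shown alone.

For the measured compounds named here, compound 2 `Cc1c(C(=O)N/N=C/c2ccccc2)no[n+]1[O-]` is one of two compounds measured here; compound 1 `Cc1c(C(=O)N/N=C/c2ccco2)no[n+]1[O-]` is the other. In an ADME assay on J774.1 cells (Mus musculus) for cytotoxicity, read by MTT assay, with a stated time of 48 h (on this read-out higher numbers stand for weaker inhibition and lower numbers for stronger inhibition), compound 1 gives only a limit, > 400000 nM. In this assay compound 2 likewise gives only a limit, > 400000 nM. The step that the two limits leave unreadable from compound 1 to compound 2 therefore cannot be read, and the limit of > 400000 nM in this assay, at which 2 of the 2 values shown sit, is all that the measured values show. Compound 3 `Cc1c(C(=O)N/N=C/c2ccc(C(F)(F)F)cc2)no[n+]1[O-]` differs from compound 2 by trifluoromethyl in place of hydrogen on an aromatic carbon. Going by the values given here, no measured step bears on this change. Compound 3 is expected to remain at the same limit, so the estimated step of a number no higher from compound 2 to compound 3 (the limit leaves the size open) is none beyond the scatter. The estimate for compound 3 in this assay is 400000 nM, within 150000 nM to 1000000 nM.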

Compound 3, half-maximal inhibitory concentration: > 400000 nM
Compound 3 gave a limit, no number; the forecaster's own chance of this, stated with the estimate: 70%; the middle value sits exactly at the limit.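

In this assay, for the compounds shown here, compound 2 and compound 3 both give only limits, so no step between them can be read. The compounds shown leave open how far beyond that shared limit any of them truly lies.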